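A few compounds are considered here, and "the series" means these few. Any claim that something is new, unique, unknown or untested is made for them only; others in the source may bear on it.

Measured compounds:
compound 1 (`COc1ccc2c(/C=C(\C#N)C(=O)c3c[nH]c4cc(F)ccc34)c[nH]c2c1`) gives 21400 nM
compound 2 (`N#C/C(=C\c1cn(Cc2ccc(Cl)cc2)c2ccc(Br)cc12)C(=O)c1c[nH]c2ccccc12`) gives 36500 nM

Within the data shown here, both values come from a functional assay on PC-3 cells (Homo sapiens) for cytotoxicity, read by WST assay, with a stated time of 48 h (a higher number here means a weaker inhibitor, a lower number a stronger inhibitor), and are the only numbers available so far. With compound 1 at 21400 nM and compound 2 at 36500 nM the two values lie within the scatter of each other, so compound 1 cannot be ranked apart from compound 2. Among the measured compounds shown here, no single-change step between measured compounds is available. Compound 3 (`COc1ccc2c(/C=C(\C#N)C(=O)c3c[nH]c4ccccc34)c[nH]c2c1`) departs from compound 1 in one place (hydrogen in place of fluoro on an aromatic carbon), with hydrogen in place of fluoro on an aromatic carbon. Without a measured step as a guide, in this assay no shift beyond the scatter is expected, in either direction. The estimated step (a 1.1-fold lower number from compound 1 to compound 3 (0.03 log units; within the scatter)) is correspondingly small. Compound 3 is expected at 20000 nM with an estimated range from 7000 nM to 60000 nM for the coming measurement.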

Compound 3, half-maximal inhibitory concentration: 12500 nM
Compound 3: middle estimate off by 1.6-fold (0.20 log units), on the high side, and the stated range covers the measured number.
By their numbers in this assay, from the lowest: compounds 3, 1 and 2 (each within the scatter of the next, the first and the last beyond it).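

Among these compounds, compound 3 gives the only single-change step among the three compounds: hydrogen in place of fluoro on an aromatic carbon of a six-membered aromatic ring of carbon only, with the rest of the core of compound 1 unaltered. In this assay this step is a 1.7-fold lower number from compound 1 to compound 3 (0.23 log units; within the scatter) so at this position the fluoro and the hydrogen cannot be told apart by this read-out. No measurement is at hand that bears on this result.

The compounds shown leave open whether an amine, a carboxylic acid or a trifluoromethyl group at this same place would move the number beyond the scatter. Going by these compounds, compound 2 differs from compound 1 and compound 3 in more than one place, so what each of its differences contributes also stays open.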